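Swapping an aryl group for a cyclohexylmethyl chain

The source may report more compounds than this note shows. Statements on the series, on what has been measured and on what is new or still open speak of the compounds shown alone.

Measured compounds:
- compound 1, `Cc1ccccc1Cc1cnc(CCc2ccc(-c3ccccc3C(=O)O)cc2)[nH]1`, 9.3 nM in an in vitro functional assay on cells for agonist activity at Bombesin receptor subtype-3 (Mus musculus), read by luminescence and calcium flux; on this read-out lower numbers stand for an effect already at smaller amounts and higher numbers for an effect only at larger amounts of compound
- compound 2, `O=C(O)c1ccccc1-c1ccc(CCc2ncc(Cc3ccc(Cl)cc3)[nH]2)cc1`, 102 nM in this assay

Compound 2 has the highest number of the two measured compounds; its nearest neighbour is compound 1, and the change between them, an 11-fold higher number from compound 1 to compound 2 (1.04 log units; beyond the scatter), is a large step. Compound 3, `O=C(O)c1ccccc1-c1ccc(CCc2ncc(CCC3CCCCC3)[nH]2)cc1`, keeps the shared core and the chain that links it to the biaryl acid, and differs from compound 2 only in the change (cyclohexylmethyl in place of 4-chlorophenyl on a saturated chain carbon bound to an aromatic carbon). Within the data shown here, the one measured step, from compound 1 to compound 2, exchanged one aryl group for another and shifted the number a great deal, so this position is sensitive to what sits on it; no measured step replaces an aromatic ring by a non-aromatic one. With little to guide the direction, the estimate for compound 3 is 150 nM, within 30 nM to 800 nM, which as a step is expected to read a 1.5-fold higher number from compound 2 to compound 3 (0.17 log units; within the scatter).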

Compound 3, half-maximal effective concentration: 33 nM
Beside the measured number, compound 3's estimate is 4.5-fold (0.66 log units) above it; the measured number falls inside the stated range.
By their numbers in this assay, from the lowest: compound 1; then compound 3; then compound 2.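

In this assay this position turns out not to need an aromatic ring: the step is a 3.1-fold lower number from compound 2 to compound 3 (0.49 log units; beyond the scatter) when cyclohexylmethyl, with the same count of heavy atoms, replaces 4-chlorophenyl. Cyclohexylmethyl does not match 2-methylphenyl, however, and a 3.5-fold higher number from compound 1 to compound 3 (0.55 log units; beyond the scatter) remains between those two groups. The non-aromatic group therefore falls between the two aromatic ones, so aromatic against non-aromatic does not alone set the order of these three compounds.

Read one bond further out, the change is 4-chlorobenzyl to 2-cyclohexylethyl, so ring type and chain length change together, and a cyclohexylmethyl group standing where the 4-chlorobenzyl sits, or a 2-phenylethyl group, would be needed to tell the two apart. No supporting data explain why these groups rank as they do.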